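Vinyl to pent-4-en-1-yl on two cores in this assay

The source may report more compounds than this note shows. Statements on the series, on what has been measured and on what is new or still open speak of the compounds shown alone.

Measured so far:
compound 1 `C=CCCCCCCOC[C@@H]1CCCN1C(=O)OC(C)(C)C`: 56700 nM
compound 2 `C=CCCCCCCCCCOC[C@@H]1CCCN1C(=O)OC(C)(C)C`: >= 100000 nM, a limit
compound 3 `C=CCCCCCCOC[C@@H]1CCCN1[S+]([O-])c1ccc(C)cc1`: 53300 nM

In a functional assay on PANC-1 cells (Homo sapiens) for inhibition, read by XTT assay, with a stated time of 72 h (on this read-out lower numbers stand for stronger inhibition and higher numbers for weaker inhibition), compound 1 gives 56700 nM and compound 3 gives 53300 nM, the two within the usual scatter of each other. For compound 2 the read-out is only a limit, not a number: >= 100000 nM, see (the limit of >= 100000 nM in this assay, at which 1 of the 3 values shown sits). The step of an at least 1.7-fold higher number from compound 1 to compound 2 (0.24 log units; that floor lies within the scatter) is the change (pent-4-en-1-yl in place of vinyl on a saturated chain carbon, six bonds along the chain from an oxygen on a saturated carbon). How the cores of compound 1 and compound 3 differ is not broken down here.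

Compound 4 `C=CCCCCCCCCCOC[C@@H]1CCCN1[S+]([O-])c1ccc(C)cc1` is not yet measured; it is compound 3 carrying the same change, (pent-4-en-1-yl in place of vinyl on a saturated chain carbon, six bonds along the chain from an oxygen on a saturated carbon), at the same place. From compound 3 the step is expected to be a 1.9-fold higher number from compound 3 to compound 4 (0.27 log units; within the scatter), beside the earlier step from compound 1 to compound 2, and may again end at the limit. Compound 4 is estimated at 100000 nM, expected between 55000 nM and 200000 nM.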

Compound 4, half-maximal inhibitory concentration: 56700 nM
For compound 4 the middle estimate is 1.8-fold (0.25 log units) above the measured one; measured number inside the range.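

In this assay, pent-4-en-1-yl in place of vinyl on the core of compound 3 gives a 1.1-fold higher number from compound 3 to compound 4 (0.03 log units; within the scatter), so no shift beyond the scatter appears on this core. Set beside the first core, this shows neither that the change carries over unchanged nor that it does not: the same change on two cores in this assay, an at least 1.7-fold higher number (0.24 log units; that floor lies within the scatter) from compound 1 to compound 2 and a 1.1-fold higher number (0.03 log units; within the scatter) from compound 3 to compound 4; the limit leaves it open whether they differ The step between the cores at the longer chain, an at least 1.7-fold lower number from compound 2 to compound 4 (0.24 log units; that floor lies within the scatter), starts from a limit for compound 2, not a number, and shows no more than a floor.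

Open, as far as these compounds go, is how the change behaves on cores other than these two. Also open, from the compounds shown here alone, is how a saturated chain, or an amine or a carboxylic acid at the chain end, would read in this assay.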